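Swapping Methylsulfanyl for Amino on the Pendant Ring

The compounds below may be only part of what the source reports. "The series", "measured", "known", "first", "only" and "open" are said of these compounds alone.

Compound 1 `COc1cc(N2C(=O)[C@@H](Oc3ccccc3)[C@H]2c2ccc(SC)cc2)cc(OC)c1OC`: 7700 nM
Compound 2 `COc1ccc(N2C(=O)[C@@H](Oc3ccccc3)[C@H]2c2ccc(OC)c(O)c2)cc1`: 49000 nM
Compound 3 `COc1ccc([C@@H]2[C@@H](Oc3ccccc3)C(=O)N2c2cc(OC)c(OC)c(OC)c2)cc1N`: 13 nM

In a functional assay on MCF7 cells (Homo sapiens) for antiproliferative activity, read by MTT assay, with stated times of 24 h and 72 h (a lower number here means a stronger inhibitor, a higher number a weaker inhibitor), compound 1 stands second highest of the three numbers. Compound 2 gives 49000 nM, a higher number and so a weaker inhibitor, a gap beyond the scatter. Compound 3 gives 13 nM, a far lower number and therefore a much stronger inhibitor, again well beyond the scatter. Compound 4 `COc1cc(N2C(=O)[C@@H](Oc3ccccc3)[C@H]2c2ccc(N)cc2)cc(OC)c1OC` has not yet been measured. It differs from compound 1 in one place: amino in place of methylsulfanyl on an aromatic carbon.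

Among the measured compounds shown here, no measured pair in this set shows this same change, so the size of the step cannot be read off directly. The expectation is a step downward, toward a stronger inhibitor, of a size beyond the scatter but far short of the distance to compound 3. Compound 4 is therefore expected to give 1500 nM, with a range from 200 nM to 15000 nM. The expected step is a 5.1-fold lower number from compound 1 to compound 4 (0.71 log units; beyond the scatter).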

Compound 4, half-maximal inhibitory concentration: 160000 nM
Compound 4: the middle estimate sits 110-fold (2.03 log units) below what was measured; measured number outside the range, above it.
By their numbers in this assay, from the lowest: compound 3; then compound 1; then compound 2; then compound 4.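

In this assay, putting amino in place of methylsulfanyl on this ring, para to a large group, is far from a neutral swap: it gives a 21-fold higher number from compound 1 to compound 4 (1.32 log units; beyond the scatter), a large weakening that lies beyond the scatter. This position therefore responds strongly to the group it carries, and between these two groups, methylsulfanyl gives much the stronger inhibitor on the core of compound 1. The data shown offer no measurement that explains why this single change has so large an effect.

On these data alone, with only these two groups compared directly at this position, it remains open how a dimethylamino or an ethylsulfanyl group would behave there. As far as these compounds go, it is also open whether the same swap would produce a step of similar size on a different core.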